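Sulfonyl substituent swap at the aryl sulfonyl position

The source may report more compounds than this note shows. Statements on the series, on what has been measured and on what is new or still open speak of the compounds shown alone.

Measured compounds:
- Compound 1 `O=C([C@@H]1CCCN(S(=O)(=O)c2ccc(S(=O)(=O)N3CC[C@@H](O)C3)cc2)C1)N1CCC(F)(F)CC1`: 135 nM
- Compound 2 `CC(C)S(=O)(=O)c1ccc(S(=O)(=O)N2CCC[C@@H](C(=O)N3CCC(F)(F)CC3)C2)cc1`: 9.1 nM

Going by the values given here, compound 2 stands lowest of the two numbers in a functional assay on MIA PaCa-2 cells (Homo sapiens) for inhibition, read by MTT assay, with a stated time of 3 days; on this read-out lower numbers stand for stronger inhibition and higher numbers for weaker inhibition; the only other measured point is compound 1, which in this assay gives 135 nM, and the step of a 15-fold lower number from compound 1 to compound 2 (1.17 log units; beyond the scatter) is the single step known for the series.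

Compound 3 `CN(C)S(=O)(=O)c1ccc(S(=O)(=O)N2CCC[C@@H](C(=O)N3CCC(F)(F)CC3)C2)cc1` is not yet measured. It differs from compound 2 by dimethylamino in place of isopropyl on a sulfonyl sulfur; cut one bond further out, the change reads isopropylsulfonyl to dimethylsulfamoyl.

Among the compounds with values here, the one measured step bears on this only loosely: it exchanged a ring-bearing sulfamoyl group carrying a hydroxyl for an isopropyl on the same sulfonyl sulfur, and moved the number a great deal. Compound 3 restores a sulfamoyl linkage but with a small, donor-free dimethylamino group, so a smaller move back toward compound 1 is expected rather than the full reversal of a 15-fold lower number from compound 1 to compound 2 (1.17 log units; beyond the scatter). For compound 3 an estimate of 25 nM is made, within 8 nM to 80 nM, corresponding to an expected step of a 2.7-fold higher number from compound 2 to compound 3 (0.44 log units; beyond the scatter).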

Compound 3, half-maximal inhibitory concentration: 72.4 nM
Beside the measured number, compound 3's estimate is 2.9-fold (0.46 log units) below it; the measured number falls inside the stated range.
By their numbers in this assay, from the lowest: compound 2; then compounds 3 and 1 (each within the scatter of the next).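

In this assay the identity of the group on the sulfonyl sulfur matters even at a matched count: isopropyl and dimethylamino each have 3 heavy atoms and 0 hydrogen-bond donors, yet the change gives an 8.0-fold higher number from compound 2 to compound 3 (0.90 log units; beyond the scatter) in this series. With a 1.9-fold lower number from compound 1 to compound 3 (0.27 log units; within the scatter), dimethylamino and 3-hydroxypyrrolidin-1-yl cannot be separated here, so among these compounds the large earlier step goes with isopropyl itself and not only with losing the hydroxyl or the ring. No measurement available here accounts for the gap between isopropyl and dimethylamino.

Still open, as far as these compounds go, is whether other carbon groups on the sulfonyl sulfur, such as cyclopropyl or tert-butyl, keep the number of compound 2. Also open, from the compounds shown here alone, is whether a plain amino group or a morpholine ring there would read like compound 3.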